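Spiro series: methoxyphenyl for bromophenyl on triazole

This account rests on a few compounds, and the source may have more. Where it says the series, first, only, none or still open, it means among the compounds named here.

Measured so far:
compound 1, `N#CC1=C(N)Oc2c(c3nc4ccccc4nc3c3ccccc23)C12C(=O)N(Cc1cnnn1-c1cccc(Cl)c1)c1ccccc12`, in a functional assay on A549 cells (Homo sapiens) for antiproliferative activity, read by MTT assay, with a stated time of 48 h; on this read-out higher numbers stand for weaker inhibition and lower numbers for stronger inhibition: 32600 nM
compound 2, `N#CC1=C(N)Oc2c(c3nc4ccccc4nc3c3ccccc23)C12C(=O)N(Cc1cnnn1-c1cccc(Br)c1)c1ccccc12`, a limit only in this assay: > 50000 nM

Compound 2 stands at the ceiling of this assay; its reading > 50000 nM is a limit of the assay, not a number, as recorded in the limit of > 50000 nM in this assay, at which 1 of the 2 values shown sits. Going by the values given here, the only measured step is an at least 1.5-fold higher number from compound 1 to compound 2 (0.18 log units; that floor lies within the scatter), which concerns the aryl on the triazole nitrogen. Compound 3, `COc1ccc(-n2nncc2CN2C(=O)C3(C(C#N)=C(N)Oc4c3c3nc5ccccc5nc3c3ccccc43)c3ccccc32)cc1`, changes that same aryl: 4-methoxyphenyl in place of 3-bromophenyl on an aromatic nitrogen. The measured step, a halogen-for-halogen swap, bears on this change only loosely, and its size cannot be set against the scatter. No step beyond the scatter is expected in either direction. The expected step is an at least 1.1-fold lower number from compound 2 to compound 3 (0.04 log units; that floor lies within the scatter). Compound 3 is estimated in this assay at 45000 nM, range 15000 nM to 150000 nM, with a fair chance that only a limit is returned.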

Compound 3, half-maximal inhibitory concentration: > 50000 nM
Compound 3 ended at the assay's limit; the forecaster's own chance of this, stated with the estimate: 50%; at least 1.1-fold (0.04 log units) between middle value and limit.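

In this assay, the 4-methoxyphenyl, the one aryl here without a halogen, leaves compound 3 at > 50000 nM, a limit of the assay and not a number. Against the only numeric reading in the set, the change from 3-chlorophenyl to 4-methoxyphenyl on the aromatic nitrogen gives an at least 1.5-fold higher number from compound 1 to compound 3 (0.18 log units; that floor lies within the scatter). The step between compound 2 and compound 3 cannot be read because both readings are limits: the limit of > 50000 nM in this assay, at which 2 of the 3 values shown sit.

Still open, on these data alone, is whether any change to this aryl can bring a reading clearly under the limit, or whether the aryl position matters at all in this assay. Also open, as far as these compounds go, is whether an amine or a carboxylic acid on the aryl, or a longer chain in its place, would give a readable number.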